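Selenium-substituted anilinoquinazolines: a methyl-to-cyano step

The compounds below may be only part of what the source reports. "The series", "measured", "known", "first", "only" and "open" are said of these compounds alone.

Measured compounds:
compound 1 `C[Se]c1ccc(N(C)c2nc(C3CC3)nc3ccccc23)cc1`, 13 nM
compound 2 `Cc1nc(N(C)c2ccc([Se]C#N)c(Cl)c2)c2ccccc2n1`, 7 nM
compound 3 `C[Se]c1ccc(N(C)c2nc(C)nc3ccccc23)cc1Cl`, 2 nM

All three were tested in a functional assay on A549 cells (Homo sapiens) for inhibition, read by MTT assay, with a stated time of 48 h; a lower number here means a stronger inhibitor, a higher number a weaker inhibitor. Compound 1 gives the highest of the three numbers; its value and that of compound 2 lie within the scatter of each other, while compound 3 lies beyond it in the lower direction.

One change is seen once among the measured pairs. From compound 3 to compound 2 the change is cyano in place of methyl on a selenium, and it made a 3.5-fold higher number from compound 3 to compound 2 (0.54 log units; beyond the scatter).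

Compound 4 `CN(c1ccc([Se]C#N)cc1)c1nc(C2CC2)nc2ccccc12` has not yet been measured. It stands to compound 1 as compound 2 stands to compound 3: the change is cyano in place of methyl on a selenium. The place lines of the two changes are the same word for word, so this is the same change, not merely the same kind. The cores of compound 1 and compound 3 differ, but that difference is not broken down here.

Among the compounds with values here, on the single precedent, the step is expected to be a 3.1-fold higher number from compound 1 to compound 4 (0.49 log units; beyond the scatter), resting on a 3.5-fold higher number from compound 3 to compound 2 (0.54 log units; beyond the scatter). Within the data shown here, compound 4 is therefore estimated at 40 nM, with a likely range from 12 nM to 130 nM; with only one prior instance, the range is kept wide.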

Compound 4, half-maximal inhibitory concentration: 12 nM
Compound 4: the middle estimate sits 3.3-fold (0.52 log units) above what was measured; low and high end bracket the measured number.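

In this assay, cyano in place of methyl on a selenium gives a 1.1-fold lower number from compound 1 to compound 4 (0.03 log units; within the scatter), so on the core of compound 1 the exchange leaves the reading within the scatter. The change therefore does not carry from one core to the other as a step of fixed size: the same change on two cores in this assay, a 3.5-fold higher number (0.54 log units; beyond the scatter) from compound 3 to compound 2 and a 1.1-fold lower number (0.03 log units; within the scatter) from compound 1 to compound 4, 3.8-fold (0.58 log units) apart, beyond the scatter of two such steps. Within the data shown here, this shows only that the step on the core of compound 3 cannot be assumed to hold on the core of compound 1; with one pair on each core, it does not show which difference between the cores goes with the gap, nor how the step would behave on any third core.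

Open, going by these compounds, is whether another group on the selenium, such as a longer chain, an amine or a carboxylic acid, would follow the cyano or the methyl on either core. Also open, on these data alone, is whether the gap between the two steps would persist on cores that differ from each other in one place only.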